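Adding Fluorine to the Styryl Arm of Compound 3

The source may report more compounds than this note shows. Statements on the series, on what has been measured and on what is new or still open speak of the compounds shown alone.

Measured compounds in a functional assay on MCF7 cells (Homo sapiens) for cytotoxicity, read by MTT assay, with a stated time of 2 days, tested at 100 uM; a higher number here means a weaker effect of the compound at the concentration tested, a lower number a stronger effect:
compound 1, `CC(=O)c1cc(-c2ccccc2)cc2cc(-c3ccccc3)[nH]c12`, gives 65.8%;
compound 2, `CC(=O)c1cc(-c2ccccc2)cc2cc(-c3ccc(F)cc3)[nH]c12`, gives 73.3%;
compound 3, `CC(=O)c1cc(/C=C/c2ccccc2)cc2cc(-c3ccc(F)cc3)[nH]c12`, gives 50.1%.

Compound 4, `CC(=O)c1cc(/C=C/c2ccc(F)cc2)cc2cc(-c3ccc(F)cc3)[nH]c12`, is not yet measured. It differs from compound 3 by fluoro in place of hydrogen on an aromatic carbon. The same change is already known between compound 1 and compound 2, where it reads fluoro in place of hydrogen on an aromatic carbon and gave a number 7.5 percentage points higher from compound 1 to compound 2 (within the scatter) in this assay. The difference between the cores of compound 1 and compound 3 is not broken down here. Compound 3 has the lowest of the three measured numbers, and its step of a number 23.2 percentage points lower from compound 2 to compound 3 (beyond the scatter) lies beyond the scatter.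

On that basis the step from compound 3 to compound 4 is expected to be small, a number 5.9 percentage points higher from compound 3 to compound 4 (within the scatter), because a number 7.5 percentage points higher from compound 1 to compound 2 (within the scatter) stayed within the scatter. Compound 4 is therefore estimated at 56%, between 40% and 72%.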

Compound 4, a percentage reported as activity, at one concentration (the size of the read-out at that concentration, not a potency): 42.2%
For compound 4 the middle estimate is 13.8 percentage points above the measured one, within the range that was stated.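

In this assay the fluoro in place of hydrogen on the 2-phenylethenyl arm gave a number 7.9 percentage points lower from compound 3 to compound 4 (within the scatter) and the full exchange of phenyl for 2-(4-fluorophenyl)ethenyl gave a number 31.1 percentage points lower from compound 2 to compound 4 (beyond the scatter) in this series. The fluoro change did not carry over unchanged from one core to the other: the same change on two cores in this assay, a number 7.5 percentage points higher (within the scatter) from compound 1 to compound 2 and a number 7.9 percentage points lower (within the scatter) from compound 3 to compound 4, 15.4 percentage points apart, beyond the scatter of two such steps. Each single fluoro step still lies within the scatter, so neither pair shows a clear effect of the change on its own, and two cores say nothing about how it would behave on a third.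

The compounds shown leave open whether an amine or a carboxylic acid in place of that fluoro would move the read-out. They also leave open whether a longer chain in place of the 2-phenylethenyl arm would do so.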